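This account rests on a few compounds, and the source may have more. Where it says the series, first, only, none or still open, it means among the compounds named here.

Measured compounds:
Compound 1, `CC1CCN(C2CCN(S(=O)(=O)c3ccc(C#N)cc3)CC2)CC1`. In an ADME assay on HCT-116 cells (Homo sapiens) for cytotoxicity, read by CellTiter-Glo, with a stated time of 72 h (a higher number here means a weaker inhibitor, a lower number a stronger inhibitor), compound 1 gives > 5000 nM; this is a limit of the assay, not a number.
Compound 2, `COc1ccccc1-c1ccc(S(=O)(=O)N2CCC(N3CCC(C)CC3)CC2)cc1`. In this assay compound 2 gives > 5000 nM, again a limit.
Compound 3, `CCCOc1ccc(S(=O)(=O)N2CCC(N3CCC(C)CC3)CC2)cc1`. In this assay compound 3 gives > 5000 nM, also a limit.

Compound 1 therefore stands at the limit of this assay, and every value shown sits at that same limit, as the limit of > 5000 nM in this assay, at which 3 of the 3 values shown sit, records. The steps a step that the two limits leave unreadable from compound 1 to compound 2, a step that the two limits leave unreadable from compound 1 to compound 3 and a step that the two limits leave unreadable from compound 2 to compound 3 cannot be read. Two limits give no size and no direction.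

Compound 4, `CC1CCN(C2CCN(S(=O)(=O)c3ccc(F)cc3F)CC2)CC1`, is not yet measured. It differs from compound 1 in one place: 2,4-difluorophenyl in place of 4-cyanophenyl on a sulfonyl sulfur. The measured steps all altered the group on the aromatic ring attached to the sulfonyl sulfur, and none of them moved the value away from the limit; the change to compound 4 exchanges the whole aryl group at that same sulfur. With nothing readable to go on, no step beyond the scatter is expected in this assay, and compound 4 is expected once more to sit at the limit.

Compound 4 is estimated at 8000 nM, with a range from 3000 nM to 30000 nM. This means the expected step that the limit leaves unreadable from compound 1 to compound 4 is essentially none.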

Compound 4, half-maximal inhibitory concentration: > 5000 nM
Compound 4: a limit, no number; the forecaster's own chance of this, stated with the estimate: 85%; the middle value is on the limit's open side.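

In this assay compound 4 gives > 5000 nM, a limit of the assay and not a number. Among these compounds, compound 1 also stands at a limit, so no step between compound 1 and compound 4 can be read. How the aryl group on the sulfonyl sulfur affects this read-out stays open, because no compound shown gives an actual number: the limit of > 5000 nM in this assay, at which 4 of the 4 values shown sit.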